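The source may report more compounds than this note shows. Statements on the series, on what has been measured and on what is new or still open speak of the compounds shown alone.

Of the compounds shown here, three sharing one core have been measured in a functional assay on PC-3 cells (Homo sapiens) for cytotoxicity, read by MTT assay, with a stated time of 48 h; a higher number here means a weaker inhibitor, a lower number a stronger inhibitor. Compound 1 `Cc1ccc(C(=O)N2N=C(c3cc4ccccc4oc3=O)CC2c2ccccc2)cc1` gives 13200 nM, compound 2 `Cc1ccc(S(=O)(=O)N2N=C(c3cc4ccccc4oc3=O)CC2c2ccccc2)cc1` gives 48600 nM, and compound 3 `CCNCC(=O)N1N=C(c2cc3ccccc3oc2=O)CC1c1ccccc1` gives 5580 nM, the lowest of the three numbers. The steps among them were a 3.7-fold higher number from compound 1 to compound 2 (0.57 log units; beyond the scatter), a 2.4-fold lower number from compound 1 to compound 3 (0.37 log units; beyond the scatter) and an 8.7-fold lower number from compound 2 to compound 3 (0.94 log units; beyond the scatter). Compound 4 `O=C(CNC1CCCCC1)N1N=C(c2cc3ccccc3oc2=O)CC1c1ccccc1` differs from compound 3 by cyclohexyl in place of ethyl on an amine nitrogen. Within the data shown here, none of the measured steps changes the group on that amine nitrogen; all three alter what sits on the amine nitrogen in the ring, so they give no direct guide to this change. An essentially unchanged number is therefore expected, with wide uncertainty, for compound 4: 4500 nM, between 1500 nM and 14000 nM, which would mean a step of a 1.2-fold lower number from compound 3 to compound 4 (0.09 log units; within the scatter), expected to fall within the scatter.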

Compound 4, half-maximal inhibitory concentration: 48500 nM
The estimate for compound 4 lay 11-fold (1.03 log units) below the measured number; the whole stated range lies below it.
By their numbers in this assay, from the lowest: compound 3; then compound 1; then compounds 4 and 2 (each within the scatter of the next).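

In this assay, the amine nitrogen outside the ring turns out to matter: cyclohexyl in place of ethyl alone gives an 8.7-fold higher number from compound 3 to compound 4 (0.94 log units; beyond the scatter). That one change removes the lead compound 3 held, leaving a 3.7-fold higher number from compound 1 to compound 4 (0.57 log units; beyond the scatter) and, with no real separation, a 1.0-fold lower number from compound 2 to compound 4 (0.00 log units; within the scatter). Nothing measured here bears on why the number moves. The compounds shown leave open how the number runs between ethyl and cyclohexyl: a propyl or cyclopentyl group on that amine nitrogen could show whether it climbs gradually or jumps.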